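The source may hold more compounds than are shown below. What is called first, only, known or untested is meant among the compounds shown, and "the series" means these compounds.

Compounds measured so far:

Compound 1 `CCCCCCCCCOc1ccccc1C(SCCC(=O)O)SCCC(=O)O` — 4090 nM
Compound 2 `O=C(O)CCSC(SCCC(=O)O)c1ccccc1OCCCCCCc1ccccc1` — 11500 nM

In an assay on membranes from lung (Cavia porcellus) for binding affinity to cysteinyl leukotriene receptor (Homo sapiens) (a higher number here means a weaker inhibitor, a lower number a stronger inhibitor), compound 2 gives 11500 nM, the higher of the two numbers recorded so far, and compound 1 sits a 2.8-fold higher number from compound 1 to compound 2 (0.45 log units; beyond the scatter) away from it in the other direction. Compound 3 `O=C(O)CCSC(SCCC(=O)O)c1ccccc1OCCCCCCCCCO` has not yet been measured. It differs from compound 2 in one place: 3-hydroxypropyl in place of phenyl on a saturated chain carbon, six bonds along the chain from an oxygen on an aromatic ring. Among the compounds with values here, the only step that bears on this is the one from compound 1 to compound 2, a 2.8-fold higher number from compound 1 to compound 2 (0.45 log units; beyond the scatter), where a phenyl took the place of a propyl at the same position and the number rose modestly. Within the data shown here, compound 3 undoes that phenyl and puts a chain of similar length in its place, now ending in a hydroxyl, so a return toward the number of compound 1 seems plausible, though the added hydroxyl has no precedent here. The estimate for compound 3 in this assay is therefore 5000 nM (range 1500 nM to 16000 nM), which is expected to amount to a 2.3-fold lower number from compound 2 to compound 3 (0.36 log units; beyond the scatter).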

Compound 3, inhibition constant: > 20000 nM
Compound 3: no number, only a limit; the forecaster's own chance of this, stated with the estimate: 5%; middle value at least 4.0-fold (0.60 log units) from the limit.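

Compound 3 gives only a limit of the assay, not a number: the limit of > 20000 nM in this assay, at which 1 of the 3 values shown sits.

Putting hydroxy in place of hydrogen on a saturated chain carbon, nine bonds along the chain from an oxygen on an aromatic ring, gives an at least 4.8-fold higher number from compound 1 to compound 3 (0.68 log units; beyond the scatter), the first sign that this far end of the chain does not accept every change. Going by these compounds, exchanging phenyl for 3-hydroxypropyl gives an at least 1.7-fold higher number from compound 2 to compound 3 (0.24 log units; that floor lies within the scatter), which shows that removing the phenyl did not bring the number back toward that of compound 1, while the true size of this step stays unknown.

On these data alone, how far compound 3 really lies past its limit remains open. Also open, as far as these compounds go, is whether an amine, a carboxylic acid or a methoxy at that chain end would behave like the hydroxy, and whether a hydroxy on a shorter chain would.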